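Nitro for Chloro: What to Expect of Compound 4

This account rests on a few compounds, and the source may have more. Where it says the series, first, only, none or still open, it means among the compounds named here.

Compound 1 `CCN(CC)C(=O)CN(c1cc(Cl)ccc1OC)S(=O)(=O)c1ccccc1` gives > 20000 nM in a functional assay on SH-SY5Y cells (Homo sapiens), read by MTT assay, with a stated time of 24 h (on this read-out lower numbers stand for an effect already at smaller amounts and higher numbers for an effect only at larger amounts of compound), which is a limit of the assay rather than a number.
Compound 2 `COc1ccc(Cl)cc1N(CC(=O)Nc1ccc(C(F)(F)F)cc1)S(=O)(=O)c1ccccc1` gives 3750 nM.
Compound 3 `COc1ccc(Cl)cc1N(CC(=O)Nc1ccc(Cl)cc1)S(=O)(=O)c1ccccc1` gives > 20000 nM, again a limit rather than a number.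

Compound 3 therefore sits at the limit, as does compound 1 (the limit of > 20000 nM in this assay, at which 2 of the 3 values shown sit); only compound 2 yields a number. Compound 4 `COc1ccc(Cl)cc1N(CC(=O)Nc1ccc([N+](=O)[O-])cc1)S(=O)(=O)c1ccccc1` differs from compound 3 by nitro in place of chloro on an aromatic carbon. Within the data shown here, no measured step involves a nitro group. The closest is an at least 5.3-fold higher number from compound 2 to compound 3 (0.72 log units; beyond the scatter), which shows that exchanging the group on that ring can shift the result beyond the scatter. an at least 5.3-fold lower number from compound 1 to compound 2 (0.72 log units; beyond the scatter) and a step that the two limits leave unreadable from compound 1 to compound 3 show that one such exchange lifts the value off the limit while the other leaves it there. Whether nitro behaves more like chloro or like trifluoromethyl cannot be read from these three compounds. The expected step is an at least 2.2-fold lower number from compound 3 to compound 4 (0.34 log units; beyond the scatter). Compound 4 is estimated at 9000 nM, within a range from 2500 nM to 30000 nM.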

Compound 4, half-maximal effective concentration: 8210 nM
Estimate against measurement, compound 4: 1.1-fold (0.04 log units) above; the measured number falls inside the stated range.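

Nitro on this ring also lifts the value off the limit, as trifluoromethyl does, with an at least 2.4-fold lower number from compound 3 to compound 4 (0.38 log units; beyond the scatter) and an at least 2.4-fold lower number from compound 1 to compound 4 (0.38 log units; beyond the scatter). Among these compounds, two groups at this place can now be compared by real numbers for the first time, and they differ: a 2.2-fold higher number from compound 2 to compound 4 (0.34 log units; beyond the scatter). Compounds 2 and 4 give numbers, while the others stay at a limit: the limit of > 20000 nM in this assay, at which 2 of the 4 values shown sit.

On these data alone, whether an amine, a nitrile or a carboxylic acid at this place would also give a number remains open. The compounds shown also leave open how large the step from chloro to nitro really is, since compound 3 gives only a limit.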